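Series notes: piperidinyl and oxetanyl side chains

The compounds below may be only part of what the source reports. "The series", "measured", "known", "first", "only" and "open" are said of these compounds alone.

Measured compounds:
- compound 1, `COc1cccc(F)c1-c1cc(C(=O)N[C@@H](CCN2CCCCC2)CC(=O)NC2CCC2)nn1C1CCCC1`: 74.3%
- compound 2, `O=C(C[C@H](CCN1CCCCC1)NC(=O)c1cc(-c2cccc[n+]2[O-])n(C2CCCC2)n1)NC1CCC1`: "nd" (no result reported)
- compound 3, `O=C(C[C@H](CCNC(=O)C1COC1)NC(=O)c1cc(-c2ccccc2C(F)(F)F)n(C2CCCC2)n1)NC1CCC1`: "nd" (no result reported)

Among the compounds with values here, in an ADME assay on microsomes from liver (Rattus norvegicus, strain Sprague-Dawley) for metabolic stability, read by LC-MS, using NADPH, with a stated time of 30 min, tested at 1 uM (on this read-out higher numbers stand for a more stable compound and lower numbers for a less stable compound), compound 1 gives 74.3%, and that is the only number in the set. In this assay compound 2 reports "nd" (no result reported) and compound 3 reports "nd" (no result reported), so compound 3 stands nowhere on the numbers shown: there is no value for it and no counted step from it to any measured compound.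

Compound 4, `O=C(C[C@H](CCN1CCCCC1)NC(=O)c1cc(-c2ccccc2C(F)(F)F)n(C2CCCC2)n1)NC1CCC1`, is the unmeasured member. It differs from compound 3 in one place: piperidin-1-yl in place of ((oxetan-3-yl)carbonyl)amino on a saturated chain carbon, three bonds along the chain from an amide-type nitrogen. With no number for compound 3, the size and direction of the step from compound 3 to compound 4 in this assay cannot be built from the data, and nothing beyond the scatter can be claimed for it.

Within the data shown here, what remains is the value of compound 1 as the only anchor, and compound 4 shares the piperidin-1-yl side chain with compound 1 while carrying a different aryl group, a pair for which no step is counted. Compound 4 is therefore estimated in this assay at 65%, expected to fall between 35% and 90%.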

Compound 4, percent of the compound remaining: 74.6%
For compound 4 the middle estimate is 9.6 percentage points below the measured one, and the stated range covers the measured number.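

In this assay, within the data shown here, 2-(trifluoromethyl)phenyl in place of 2-fluoro-6-methoxyphenyl on an aromatic carbon, with the piperidin-1-yl side chain held constant, gives a number 0.3 percentage points higher from compound 1 to compound 4 (within the scatter), the first counted step. At this position the two aryl groups are therefore not told apart by this read-out, though this single pair supports no wider pattern. No available evidence bears on why this aryl change leaves the read-out within the scatter.

The steps involving compound 2 and compound 3 cannot be read, so the change from ((oxetan-3-yl)carbonyl)amino to piperidin-1-yl on the chain has no size here. As far as these compounds go, whether a plain phenyl group at the aryl position, or morpholin-4-yl on the chain, would fit the same picture remains open.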